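Adding a Nitrile to the Pyridine of Compound 3

The compounds below may be only part of what the source reports. "The series", "measured", "known", "first", "only" and "open" are said of these compounds alone.

Three amides sharing one core have been tested in a functional assay for antagonist activity at transient receptor potential cation channel subfamily V member 1 (Homo sapiens), read by FLIPR; a lower number here means a stronger inhibitor, a higher number a weaker inhibitor. Compound 1 `N#Cc1ccc(NC(=O)c2ccc(-c3ncccc3C(F)(F)F)cc2)cc1` gives 417 nM in this assay, compound 2 `Cc1cccnc1-c1ccc(C(=O)Nc2ccc(C(C)C)cc2)cc1` gives 73 nM, and compound 3 `CC(C)(C)c1ccc(NC(=O)c2ccc(-c3ccccn3)cc2)cc1` gives 11 nM. Compound 3 thus has the lowest number of the three; its gap to compound 2 and its larger gap to compound 1 both lie beyond the usual scatter. Compound 4 `CC(C)(C)c1ccc(NC(=O)c2ccc(-c3ncccc3C#N)cc2)cc1` differs from compound 3 in one place: cyano in place of hydrogen on an aromatic carbon. Among the measured compounds shown here, no pair of measured compounds isolates this change, and compounds 1 and 2 differ from compound 3 in two places at once. The step from compound 3 to compound 4 is expected to be a modest weakening, a 2.3-fold higher number from compound 3 to compound 4 (0.36 log units; beyond the scatter). Compound 4 is therefore estimated at 25 nM, within a range from 7 nM to 90 nM.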

Compound 4, half-maximal inhibitory concentration: 30 nM
The estimate for compound 4 lay 1.2-fold (0.08 log units) below the measured number; measured number inside the range.
By their numbers in this assay, from the lowest: compound 3; then compound 4; then compound 2; then compound 1.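

In this assay, among the compounds shown here, a 2.7-fold higher number from compound 3 to compound 4 (0.44 log units; beyond the scatter) gives the first direct reading of this change. A cyano group on this aromatic carbon, ortho to a large group and two atoms from the ring nitrogen, costs only a modest loss of inhibition, and compound 4 stays at 30 nM. Nothing measured here explains the step. As far as these compounds go, whether an amine or a carboxylic acid on this same carbon would raise or lower the number remains open. So does the effect of the same cyano group on the other amides.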